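Methyl in place of chloro: an expected limit

The source may report more compounds than this note shows. Statements on the series, on what has been measured and on what is new or still open speak of the compounds shown alone.

Compound 1 (`Cc1c(O)ccc2c1[C@H](Cn1cc(-c3ccc(Cl)cc3)nn1)[C@@]13CC(=O)[C@@](C)(CC[C@@H]21)C3`): in a functional assay on SMMC-7721 cells (Homo sapiens) for cytotoxicity, read by MTT assay, with a stated time of 4 days (a lower number here means a stronger inhibitor, a higher number a weaker inhibitor), compound 1 gives only a limit, > 20000 nM.
Compound 2 (`Cc1ccc(S(=O)(=O)Oc2ccc3c(c2C)[C@H](Cn2cc(-c4ccc(Cl)cc4)nn2)[C@@]24CC(=O)[C@@](C)(CC[C@@H]32)C4)cc1`): in this assay compound 2 gives only a limit, > 20000 nM.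
Compound 3 (`C=C1C[C@]23C[C@@]1(O)CC[C@@H]2c1cccc(C)c1[C@@H]3Cn1cc(-c2ccc(F)cc2)nn1`): in this assay compound 3 gives only a limit, > 20000 nM.

Compound 2 therefore stands nowhere in particular among the numbers: every value shown sits at the same limit, as the limit of > 20000 nM in this assay, at which 3 of the 3 values shown sit, records. Among the measured compounds shown here, the single measured step, from compound 1 to compound 2 with (4-methylphenyl)sulfonyl in place of hydrogen on an oxygen on an aromatic ring, is a step that the two limits leave unreadable from compound 1 to compound 2.

Compound 4 (`Cc1ccc(-c2cn(C[C@H]3c4c(ccc(OS(=O)(=O)c5ccc(C)cc5)c4C)[C@@H]4CC[C@@]5(C)C[C@]43CC5=O)nn2)cc1`) differs from compound 2 by methyl in place of chloro on an aromatic carbon. For the measured compounds named here, no measured step touches this position, and the one step that exists reads as nothing. With three limits and no readable change anywhere, the step from compound 2 to compound 4 in this assay is expected to be a step that the limit leaves unreadable from compound 2 to compound 4, that is, no shift beyond the scatter. Compound 4 is accordingly estimated at 30000 nM, within 12000 nM to 100000 nM, most probably reported again only as a limit.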

Compound 4, half-maximal inhibitory concentration: > 20000 nM
Compound 4 gave a limit, no number (the forecaster's own chance of this, stated with the estimate: 85%); the middle value lies beyond the limit too.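

Compound 2 and compound 4 each give only a limit, and the step between them cannot be read. The compounds shown leave open whether methyl in place of chloro changes anything in this assay, where every value shown is a limit rather than a number.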